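The source may report more compounds than this note shows. Statements on the series, on what has been measured and on what is new or still open speak of the compounds shown alone.

Of the compounds shown here, three built on one shared core have been measured in a functional assay on CHO cells with adenosine receptor A1 (Homo sapiens) as the target, read by cAMP accumulation and immunoassay, with a stated time of 6 min, tested at 1 uM; on this read-out lower numbers stand for a stronger effect and higher numbers for a weaker effect at the one concentration tested. Compound 1 `Nc1scc(CN2CCN(c3ccccc3C(F)(F)F)CC2)c1C(=O)c1ccc(Cl)cc1` gives -39% in this assay. Compound 2 `Nc1scc(CN2CCN(c3ccc(Cl)c(C(F)(F)F)c3)CC2)c1C(=O)c1ccc(Cl)cc1` gives -47%. Compound 3 `Nc1scc(CN2CCN(C3CCCCCC3)CC2)c1C(=O)c1ccc(Cl)cc1` gives 3.7%. Compound 3 thus stands highest of the three numbers, and since lower numbers mean a stronger effect, it shows the weakest effect of the three. The step of a number 42.7 percentage points higher from compound 1 to compound 3 (beyond the scatter) and the step of a number 50.7 percentage points higher from compound 2 to compound 3 (beyond the scatter) both show that putting cycloheptyl in place of a 2-(trifluoromethyl)phenyl or a 4-chloro-3-(trifluoromethyl)phenyl group on the amine nitrogen in a ring lifted the number far beyond the scatter, whereas a number 8 percentage points lower from compound 1 to compound 2 (within the scatter) shows that swapping one of those two groups for the other changed little.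

Compound 4 `Nc1scc(CN2CCN(c3c(F)cccc3F)CC2)c1C(=O)c1ccc(Cl)cc1` has not yet been measured. Its change from compound 3 is 2,6-difluorophenyl in place of cycloheptyl on an amine nitrogen in a ring. This reverses the kind of change seen in the two large steps: a six-membered aromatic ring returns to the amine nitrogen in place of the seven-membered non-aromatic ring. Because a number 42.7 percentage points higher from compound 1 to compound 3 (beyond the scatter) and a number 50.7 percentage points higher from compound 2 to compound 3 (beyond the scatter) ran upward when the aromatic ring left, a downward step of comparable size is expected when one returns, and the closeness of compound 1 and compound 2 supports a number near theirs. The step of a number 38.7 percentage points lower from compound 3 to compound 4 (beyond the scatter) is therefore expected. For compound 4 a value of -35% is estimated, with a range from -65% to 0%.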

Compound 4, a percentage reported as activity, at one concentration (the size of the read-out at that concentration, not a potency): -65%
The estimate for compound 4 lay 30 percentage points above the measured number; the range from low to high includes it.
By their numbers in this assay, from the lowest: compound 4; then compounds 2 and 1 (each within the scatter of the next); then compound 3.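

With a number 68.7 percentage points lower from compound 3 to compound 4 (beyond the scatter) as a third example, each of the three compounds with a substituted phenyl on the ring nitrogen now gives a lower number than cycloheptyl in this assay, and none of the four compounds goes against this. What is new is that these phenyl groups no longer all read alike: a number 18 percentage points lower from compound 2 to compound 4 (beyond the scatter) and a number 26 percentage points lower from compound 1 to compound 4 (beyond the scatter) show that the groups carried on the aromatic ring can shift the result at this position, whereas the two earlier aromatic compounds could not be told apart. Compound 4 therefore shows the strongest effect of the four at the one concentration tested, so 2,6-difluorophenyl is the best of these groups on this read-out, though a single concentration gives no potency.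

The change from cycloheptyl to 2,6-difluorophenyl alters ring size and aromatic character together, so cyclohexyl would help to separate the two, while plain phenyl and a phenyl with one fluorine would show what each fluorine adds. Nothing measured here explains why 2,6-difluorophenyl gives the lowest number.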